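Isopropylamino replacing isopropoxy on a fused sulfonyl ring core

The compounds below may be only part of what the source reports. "The series", "measured", "known", "first", "only" and "open" are said of these compounds alone.

The two compounds with measured values:
Compound 1, `CC(C)SC1=NS(=O)(=O)c2cc(Cl)ccc2N1`: 98.8%
Compound 2, `CC(C)OC1=NS(=O)(=O)c2cc(Cl)ccc2N1`: 88%

In a functional assay on the whole organism (uterus, Rattus norvegicus, strain Wistar) for inhibition, tested at 10 uM (on this read-out higher numbers stand for a weaker effect at the one concentration tested and lower numbers for a stronger effect), compound 2 gives 88%, the lower of the two numbers in hand, and its nearest neighbour is compound 1, which in this assay gives 98.8%. Among the compounds with values here, the one step available, a number 10.8 percentage points lower from compound 1 to compound 2 (beyond the scatter), came from an isopropoxy in place of an isopropylsulfanyl on a carbon with a double bond to nitrogen. Compound 3, `CC(C)NC1=NS(=O)(=O)c2cc(Cl)ccc2N1`, has not yet been measured; it differs from compound 2 by isopropylamino in place of isopropoxy on a carbon with a double bond to nitrogen. Within the data shown here, no measured step covers an isopropylamino at this position, so the only guide is that the single prior swap at the same carbon shifted the read-out modestly. Compound 3 is therefore expected to stay near compound 2, with a step of a number 4 percentage points lower from compound 2 to compound 3 (within the scatter) in this assay, and its estimated value is 84% within a range of 55% to 100%.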

Compound 3, a percentage reported as activity, at one concentration (the size of the read-out at that concentration, not a potency): 94.4%
For compound 3 the middle estimate is 10.4 percentage points below the measured one; measured number inside the range.
By their numbers in this assay, from the lowest: compounds 2, 3 and 1 (each within the scatter of the next, the first and the last beyond it).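

In this assay, the isopropylamino group, which brings a hydrogen-bond donor to this carbon where isopropoxy has none, gives no step beyond the scatter from either neighbour (a number 6.4 percentage points higher from compound 2 to compound 3 (within the scatter); a number 4.4 percentage points lower from compound 1 to compound 3 (within the scatter)). Compound 3 therefore overlaps both compound 1 and compound 2, even though those two lie beyond the scatter of each other, so the earlier step no longer reads as a clean separation among the groups tried at this position. No measurement here accounts for this outcome.

The compounds shown leave open whether a longer chain on the nitrogen, a cyclic amine such as pyrrolidine, or a dimethylamino group at this carbon would give a number clearly below that of compound 2. They also leave open how any of these compounds would behave at other concentrations.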